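From Thiophen-2-yl to Methylcarbamoyl: an Expected Clearance Shift

The source may hold more compounds than are shown below. What is called first, only, known or untested is meant among the compounds shown, and "the series" means these compounds.

Three compounds share one core and differ only in the group on an amine nitrogen in a ring. Compound 1 `CC(=O)N1CCC(c2cc3c(-c4ccc(=O)n(C(C)C)c4)ccnc3[nH]2)CC1` carries an acetyl there and in an ADME assay on cells (Hepatocyte, Rattus norvegicus) for metabolic stability (on this read-out higher numbers stand for fast clearance and lower numbers for slow clearance), compound 1 gives 2.8 uL/min. Compound 2 `CC(C)n1cc(-c2ccnc3[nH]c(C4CCN(CC(=O)N5CCCCC5)CC4)cc23)ccc1=O` gives 26 uL/min, and compound 3 `CC(C)n1cc(-c2ccnc3[nH]c(C4CCN(Cc5cccs5)CC4)cc23)ccc1=O` gives 43 uL/min, which is the highest of the three numbers, though a 1.7-fold higher number from compound 2 to compound 3 (0.22 log units; within the scatter). The gap to compound 1 is wider: a 15-fold higher number from compound 1 to compound 3 (1.19 log units; beyond the scatter).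

Compound 4 `CNC(=O)CN1CCC(c2cc3c(-c4ccc(=O)n(C(C)C)c4)ccnc3[nH]2)CC1` has not been measured. Its difference from compound 3 is methylcarbamoyl in place of thiophen-2-yl on a saturated chain carbon bound to an amine nitrogen in a ring. The new group resembles the (piperidin-1-yl)carbonyl of compound 2 more than the thiophen-2-yl of compound 3, and compound 2 sat somewhat lower, while the acetyl of compound 1 sat far lower still, a 9.3-fold higher number from compound 1 to compound 2 (0.97 log units; beyond the scatter) being the step between those two. A lower number is therefore expected for compound 4, with a 3.6-fold lower number from compound 3 to compound 4 (0.55 log units; beyond the scatter) as the expected step. Compound 4 is estimated at 12 uL/min, in the range 3.5 uL/min to 35 uL/min.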

Compound 4, intrinsic clearance in a liver preparation (reported as CLH), per the amount of preparation that the assay uses: 8.9 uL/min
The estimate for compound 4 lay 1.3-fold (0.13 log units) above the measured number, and the stated range covers the measured number.
By their numbers in this assay, from the lowest: compound 1; then compound 4; then compounds 2 and 3 (each within the scatter of the next).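

In this assay, methylcarbamoyl in place of thiophen-2-yl gives a 4.8-fold lower number from compound 3 to compound 4 (0.68 log units; beyond the scatter) and methylamino in place of piperidin-1-yl on the carbonyl carbon gives a 2.9-fold lower number from compound 2 to compound 4 (0.47 log units; beyond the scatter) so a carbonyl alone does not set the number at this position, and the two compounds with a ring in this group, compound 2 and compound 3, both stand above compound 4. Removing that ring does not reach the level of the acetyl, since the step of a 3.2-fold higher number from compound 1 to compound 4 (0.50 log units; beyond the scatter) keeps compound 1 lowest of the four. No measurement here explains these shifts. Going by these compounds, it remains open whether the amide hydrogen of compound 4 matters, which a dimethylamino group on the same carbonyl carbon would test. On these data alone, a carboxylic acid, an amine or a longer chain at this position also remains untested in these compounds.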